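This account rests on a few compounds, and the source may have more. Where it says the series, first, only, none or still open, it means among the compounds named here.

Only part of this small series has a usable result in a functional assay on A549 cells (Homo sapiens) for cytotoxicity, read by MTT assay, with a stated time of 48 h; a higher number here means a weaker inhibitor, a lower number a stronger inhibitor. For the measured compounds named here, compound 2 `COc1c(OCCCCNCc2ccccc2)cc(O)c2c(=O)cc(-c3ccccc3)oc12` gives 4590 nM, the only actual number available. Compound 1 `CN1CCN(CCCCOc2c(O)cc(O)c3c(=O)cc(-c4ccccc4)oc23)CC1`, which carries no benzylamino group, reads > 100000 nM, a limit of the assay and not a number. For compound 3 `CNCCOc1c(O)cc(O)c2c(=O)cc(-c3ccccc3)oc12` the entry is "not determined" (no result reported).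

Compound 4 `CCN(CC)CCCCOc1cc(O)c2c(=O)cc(-c3ccccc3)oc2c1OC` has yet to be measured. It differs from compound 2 by diethylamino in place of benzylamino on a saturated chain carbon, four bonds along the chain from an oxygen on an aromatic ring.

Going by the values given here, no measured pair isolates this swap, so the size of the step is a judgement. Compound 1 also lacks benzylamino and stands at the limit > 100000 nM, although it differs elsewhere too, so a moderate move toward weaker inhibition is expected. The expected change is a 2.2-fold higher number from compound 2 to compound 4 (0.34 log units; beyond the scatter). In this assay, the estimate for compound 4 is 10000 nM, with an expected range from 3000 nM to 35000 nM.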

Compound 4, half-maximal inhibitory concentration: 1000 nM
The estimate for compound 4 lay 10-fold (1.00 log units) above the measured number; measured number below the stated range.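

In this assay, replacing benzylamino with diethylamino on a saturated chain carbon, four bonds along the chain from an oxygen on an aromatic ring, gives a 4.6-fold lower number from compound 2 to compound 4 (0.66 log units; beyond the scatter). For the compounds shown here, this is the first measured size for a change at this position, and it shows that the aromatic ring of benzylamino and its hydrogen-bond donor are not needed for a measurable result. Compound 1 remains a limit and not a number, so it gives no second measure of the size of this change: the limit of > 100000 nM in this assay, at which 1 of the 4 values shown sits.

Going by these compounds alone, the single step removes the ring and the donor together, so their separate contributions stay open. An ethylamino group on the same chain would keep the amine hydrogen without the ring, and a longer chain would test whether the four-carbon spacing matters.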